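This account rests on a few compounds, and the source may have more. Where it says the series, first, only, none or still open, it means among the compounds named here.

Compound 1 `COc1ccc([C@H]2CC(=O)N(c3cccc(C#N)c3)C2)cc1OC1CCCC1`, compound 2 `COc1ccc([C@H]2CC(=O)N(c3cccc(C(F)(F)F)c3)C2)cc1OC1CCCC1` and compound 3 `COc1ccc([C@H]2CC(=O)N(c3cccc(NS(=O)(=O)c4cccc(Cl)c4C)c3)C2)cc1OC1CCCC1` share one core and differ only in the group carried on an aromatic carbon. In a functional assay on HEK293 cells (Homo sapiens) for cytotoxicity (a higher number here means that more compound is tolerated, a lower number that less compound is tolerated), compound 1 gives > 10000 nM, which is a limit of the assay rather than a number. Compound 2 likewise reaches only the limit > 10000 nM in this assay. Compound 3 in turn sits at the limit > 10000 nM. Because (the limit of > 10000 nM in this assay, at which 3 of the 3 values shown sit), none of the steps between these three compounds can be read: a step that the two limits leave unreadable from compound 1 to compound 2, a step that the two limits leave unreadable from compound 1 to compound 3 and a step that the two limits leave unreadable from compound 2 to compound 3 all stay without a size. Compound 3 thus stands where the other two stand, at the limit, and no order among them can be drawn.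

Compound 4 `COc1ccc([C@H]2CC(=O)N(c3cccc(NS(=O)(=O)c4cccc(C)c4)c3)C2)cc1OC1CCCC1` differs from compound 3 in one place: 3-methylphenyl in place of 3-chloro-2-methylphenyl on a sulfonyl sulfur. Among the compounds with values here, no measured step shows what this exchange does in this assay, and the three steps that are known are themselves unreadable. The expectation for compound 4 therefore rests on compound 3 sitting at the limit > 10000 nM and on the unreadable steps around it. The step that the limit leaves unreadable from compound 3 to compound 4 is expected to be none beyond the scatter. Compound 4 is estimated to give about 15000 nM, within 7000 nM to 40000 nM, and most likely to be reported again only as a limit.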

Compound 4, half-maximal cytotoxic concentration: > 10000 nM
Compound 4 was reported as a limit; the forecaster's own chance of this, stated with the estimate: 85%; the middle value lies beyond the limit too.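

The steps from compound 1, compound 2 and compound 3 to compound 4 cannot be read, because compound 4 also stands at a limit in this assay and no size follows: the limit of > 10000 nM in this assay, at which 4 of the 4 values shown sit. The compounds shown leave open whether any of these groups on the shared core changes what is tolerated in this assay at all.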